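Removing the para chloro from the benzamide of compound 2

The source may report more compounds than this note shows. Statements on the series, on what has been measured and on what is new or still open speak of the compounds shown alone.

Compound 1 `O=C(Nc1ccc(Cl)c(-c2nnc3c(Cl)cccn23)c1)c1ccc(C(F)(F)F)cc1Cl` and compound 2 `O=C(Nc1ccc(Cl)c(-c2nnc3c(Cl)cccn23)c1)c1ccc(Cl)cc1` share the same amine-bearing core and differ only in the benzoyl part. In a functional assay on A549 cells (Homo sapiens) for antiproliferative activity, read by MTT assay, with a stated time of 72 h (on this read-out lower numbers stand for stronger inhibition and higher numbers for weaker inhibition), compound 1 reaches only a limit of the assay, > 100000 nM. In this assay compound 2 gives 73600 nM. Going by the values given here, compound 2 therefore holds the only number in this small set, while the other value shown sits at the limit of > 100000 nM in this assay, at which 1 of the 2 values shown sits. Compound 3 `O=C(Nc1ccc(Cl)c(-c2nnc3c(Cl)cccn23)c1)c1ccccc1` differs from compound 2 by hydrogen in place of chloro on an aromatic carbon, para to a large group. Among the compounds with values here, no measured pair of this kind is available, so the size of the step rests on the structures alone; a small step toward weaker inhibition, or none beyond the usual scatter, is expected. In this assay compound 3 is expected to give 95000 nM, with a likely range from 40000 nM to 220000 nM. This estimate amounts to an expected step of a 1.3-fold higher number from compound 2 to compound 3 (0.11 log units; within the scatter).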

Compound 3, half-maximal inhibitory concentration: 76900 nM
For compound 3 the middle estimate is 1.2-fold (0.09 log units) above the measured one, and the stated range covers the measured number.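

Going by these compounds alone, this is the first step in the set that changes one place alone, and it shows that the chloro para to a large group can be replaced by hydrogen without a readable effect (a 1.0-fold higher number from compound 2 to compound 3 (0.02 log units; within the scatter)). In this assay, 4-chlorophenyl and phenyl therefore cannot be told apart on the benzamide of this series. The pair also has to be read against the ceiling of the read-out: the limit of > 100000 nM in this assay, at which 1 of the 3 values shown sits.

Going by these compounds, whether any other group at this place, such as a methoxy, an amine or a carboxylic acid, would move the number remains open. So does the part played by the two chloro groups on the shared core, for which the compounds shown offer no step.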